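Nitro in place of methoxy on compound 3

The source may report more compounds than this note shows. Statements on the series, on what has been measured and on what is new or still open speak of the compounds shown alone.

Of the compounds shown here, three have been measured in a functional assay on the whole organism (Abdomen, strain Swiss) for inhibition, with Mus musculus as the target, with stated times of 30 min, 10 min and 5 min, at a dose of 40 mg/kg by the oral route; on this read-out higher numbers stand for a stronger effect at the one dose given and lower numbers for a weaker effect. Compound 1 `CCCCC(=O)c1c(C)nn(CCCN2CCN(c3ccc(C)cc3)CC2)c(=O)c1N` gives 15% in this assay. Compound 2 `Cc1c(C#N)c(-c2ccccc2)nn1CCCN1CCN(c2cccc(Cl)c2)CC1` gives 23%, and compound 3 `COc1cccc(N2CCN(CCCn3nc(-c4ccccc4)c(C#N)c3C)CC2)c1` gives 34%, the highest of the three numbers, with compound 2 nearest to it and compound 1 furthest from it. Within the data shown here, the only step between compounds that differ in one place is a number 11 percentage points higher from compound 2 to compound 3 (beyond the scatter), which lies beyond the scatter but is modest in size.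

Compound 4 `Cc1c(C#N)c(-c2ccccc2)nn1CCCN1CCN(c2ccc([N+](=O)[O-])cc2)CC1` has not yet been measured. It differs from compound 3 in one place: 4-nitrophenyl in place of 3-methoxyphenyl on an amine nitrogen in a ring. Among the measured compounds shown here, the step of a number 11 percentage points higher from compound 2 to compound 3 (beyond the scatter) is the one comparison that bears on it, as it also exchanges the group on the same aromatic ring; but that step swapped one kind of group for another, and no measured compound carries a nitrophenyl at all, so the direction of the new step is left open. The account therefore expects a step of a number 4 percentage points lower from compound 3 to compound 4 (within the scatter) for compound 4, a change within or only just beyond the scatter. On that basis compound 4 is estimated at 30% in this assay, with a range from 15% to 45%.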

Compound 4, a percentage reported as inhibition, in the whole organism at one dose (the size of the read-out at that dose, not a potency): 49%
Compound 4: middle estimate off by 19 percentage points, on the low side; measured number above the stated range.
By their numbers in this assay, from the lowest: compounds 1 and 2 (each within the scatter of the next); then compound 3; then compound 4.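

At this place, on an amine nitrogen in a ring, the earlier compounds had shown only the modest rise from a 3-chlorophenyl to a 3-methoxyphenyl group; the 4-nitrophenyl group now takes the number in this assay past both, with a step of a number 15 percentage points higher from compound 3 to compound 4 (beyond the scatter) and a larger one of a number 26 percentage points higher from compound 2 to compound 4 (beyond the scatter). Among compound 2, compound 3 and compound 4, which share the rest of their structure, this aryl group alone therefore separates three distinct levels, each beyond the scatter, so the read-out at the one oral dose clearly responds to what this phenyl ring carries. Nothing at hand gives a reason for the rise to compound 4.

The change to compound 4 alters both the group and its numbered place on the phenyl ring, as the names 3-methoxyphenyl and 4-nitrophenyl show, so these compounds cannot tell how much of the step belongs to the nitro group and how much to where it stands. Nor do they show whether an amine or a carboxylic acid on that phenyl ring would hold this level, or whether the rise would carry over to a longer chain in place of the three-carbon link to the shared core.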